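The compounds below may be only part of what the source reports. "The series", "measured", "known", "first", "only" and "open" are said of these compounds alone.

Compound 1 `Cc1ccc(C#N)c(OC(C)(C)C2OCC(C/C=C\CCC(=O)O)C(c3cccnc3)O2)c1` sits at the assay limit in an assay for inhibition of prostacyclin synthase (Homo sapiens), using microsomes (a higher number here means a weaker inhibitor, a lower number a stronger inhibitor), giving > 100000 nM.
Compound 2 `CC(C)(Oc1ccc(F)cc1)C1OCC(C/C=C\CCC(=O)O)C(c2cccnc2)O1` gives 2000 nM in this assay.
Compound 3 `CC(C)(Oc1ccccc1O)C1OCC(C/C=C\CCC(=O)O)C(c2cccnc2)O1` also sits at the limit, giving > 100000 nM in this assay.

Compound 3 therefore shows only a limit, not a number, and it shares that limit with one other compound (the limit of > 100000 nM in this assay, at which 2 of the 3 values shown sit). Compound 4 `CC(C)(Cc1ccc(F)cc1C#N)C1OCC(C/C=C\CCC(=O)O)C(c2cccnc2)O1` carries a group of 10 heavy atoms (8 carbon, 1 nitrogen, 1 fluorine; one six-membered aromatic ring of carbon only) in place of a group of 8 heavy atoms (6 carbon, 2 oxygen; one six-membered aromatic ring of carbon only), on a saturated chain carbon bound to two saturated chain carbons and a saturated ring carbon. Of the measured steps, an at least 50-fold higher number from compound 2 to compound 3 (1.69 log units; beyond the scatter) and an at least 50-fold lower number from compound 1 to compound 2 (1.69 log units; beyond the scatter) were both large, while a step that the two limits leave unreadable from compound 1 to compound 3 cannot be read. Going by the values given here, no measured step exchanges the oxygen for a carbon, and compound 1, which also carries a nitrile on its aryl group, reached only the limit > 100000 nM. The step is expected to be an at least 2.0-fold lower number from compound 3 to compound 4 (0.30 log units; that floor lies within the scatter), with little confidence. Compound 4 is expected at 50000 nM, within a range from 5000 nM to 200000 nM.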

Compound 4, half-maximal inhibitory concentration: 7000 nM
For compound 4 the middle estimate is 7.1-fold (0.85 log units) above the measured one, within the range that was stated.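

A nitrile-bearing aryl group can give a readable number at this position on the saturated chain carbon, with an at least 14-fold lower number from compound 1 to compound 4 (1.15 log units; beyond the scatter) and an at least 14-fold lower number from compound 3 to compound 4 (1.15 log units; beyond the scatter). It does not match the 4-fluorophenyl group on oxygen, with a 3.5-fold higher number from compound 2 to compound 4 (0.54 log units; beyond the scatter). The first two steps start from a limit, not from a number: the limit of > 100000 nM in this assay, at which 2 of the 4 values shown sit.

Each step changes several atoms at once, so the separate shares of the linking carbon, the nitrile and the fluorine stay unresolved. As far as these compounds go, how an amine or a carboxylic acid on the aryl ring would fare also remains open.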